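Two measured compounds and an expected value for a third

The compounds below may be only part of what the source reports. "The series", "measured", "known", "first", "only" and "open" are said of these compounds alone.

compound 1, `Cc1ccsc1-c1cc(-c2ccco2)cc(-c2ccc(Cl)cc2)n1`: 1%
compound 2, `Cc1ccsc1-c1cc(-c2ccc(Cl)o2)cc(-c2ccco2)n1`: 7.8%

In an assay on isolated protein for inhibition of DNA topoisomerase 1 (Homo sapiens), with a stated time of 30 min, tested at 100 uM (on this read-out higher numbers stand for more inhibition at the one concentration tested (going by the name of the read-out) and lower numbers for less inhibition), compound 1 gives 1% and, in the same assay, compound 2 gives 7.8%. Compound 2 holds the larger of the two figures, yet the gap to compound 1 lies within the scatter, so the two compounds read alike. Among the measured compounds shown here, compound 3 `Cc1ccsc1-c1cc(-c2ccc(Cl)o2)cc(-c2ccc(Cl)cc2)n1` differs from compound 2 by 4-chlorophenyl in place of furan-2-yl on an aromatic carbon; no pair of measured compounds shows this change, so no measured step can be cited for it. Compound 3 is expected to sit close to compound 2 because compound 2 gives 7.8%, with a step of a number 0.2 percentage points higher from compound 2 to compound 3 (within the scatter) not beyond the scatter. For compound 3 the estimate is 8%, ranging from 0% to 25%.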

Compound 3, a percentage reported as inhibition, at one concentration (the size of the read-out at that concentration, not a potency): 5.1%
Compound 3: the middle estimate sits 2.9 percentage points above what was measured; the range from low to high includes it.
By their numbers in this assay, from the lowest: compounds 1, 3 and 2 (each within the scatter of the next).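

In this assay, 4-chlorophenyl in place of furan-2-yl on the aromatic carbon next to the ring nitrogen gives a number 2.7 percentage points lower from compound 2 to compound 3 (within the scatter) and so shows that this position holds either ring with no step beyond the scatter. Going from furan-2-yl to 5-chlorofuran-2-yl gives a number 4.1 percentage points higher from compound 1 to compound 3 (within the scatter) and likewise stays inside the scatter. Nothing available explains either reading.

Open, on these data alone, is whether an amine or a carboxylic acid on this same aromatic carbon would give a step beyond the scatter.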